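Aryl ether variation on a pyrazole ester scaffold

The compounds below may be only part of what the source reports. "The series", "measured", "known", "first", "only" and "open" are said of these compounds alone.

Compound 1 `CCOC(=O)c1c(-c2ccccc2)nn(-c2ccccc2)c1Cn1cnc2ccccc21` and compound 2 `CCOC(=O)c1c(-c2ccccc2)nn(-c2ccccc2)c1COc1cc(OC)c(C=O)c(OC)c1` share the core of compound 1. In an assay for inhibition of Alpha amylase (Homo sapiens), with a stated time of 30 min (a higher number here means a weaker inhibitor, a lower number a stronger inhibitor), compound 1 gives 35 ug/mL, and in this assay compound 2 gives 40 ug/mL; these two numbers lie within the usual scatter of each other, so neither is set apart. Compound 3 `CCOC(=O)c1c(-c2ccccc2)nn(-c2ccccc2)c1COc1ccc(C=O)cc1OC` carries a group of 10 heavy atoms (8 carbon, 2 oxygen; one six-membered aromatic ring of carbon only) in place of a group of 12 heavy atoms (9 carbon, 3 oxygen; one six-membered aromatic ring of carbon only), on an oxygen on a saturated carbon. Among the measured compounds shown here, with no step between measured compounds to draw on, no change beyond the scatter is expected from compound 2 to compound 3 in this assay, an expected step of no change at the digits printed from compound 2 to compound 3 (within the scatter). Compound 3 is therefore estimated at 40 ug/mL in this assay, with a range from 20 ug/mL to 80 ug/mL.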

Compound 3, half-maximal inhibitory concentration: 60 ug/mL
Beside the measured number, compound 3's estimate is 1.5-fold (0.18 log units) below it; the range from low to high includes it.
By their numbers in this assay, from the lowest: compounds 1, 2 and 3 (each within the scatter of the next).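

In this assay, 4-formyl-2-methoxyphenyl in place of the group of 12 heavy atoms, on an oxygen on a saturated carbon, gives a 1.5-fold higher number from compound 2 to compound 3 (0.18 log units; within the scatter) and so sets neither compound apart. Likewise, 4-formyl-2-methoxyphenoxy in place of 1H-benzimidazol-1-yl on a saturated chain carbon bound to an aromatic carbon gives a 1.7-fold higher number from compound 1 to compound 3 (0.23 log units; within the scatter) and leaves these two groups unseparated. No evidence is available to account for these results. Going by these compounds, it remains open whether an amine or a carboxylic acid in place of the formyl group would shift the number beyond the scatter.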